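The source may report more compounds than this note shows. Statements on the series, on what has been measured and on what is new or still open speak of the compounds shown alone.

Compound 1 `O=C(CN1CCNCC1)N1CCC(NS(=O)(=O)c2cc(S(=O)(=O)c3ccccc3)ccc2C(F)(F)F)CC1` is the starting point. Among the compounds with values here, in a physicochemical assay for solubility (a higher number here means a more soluble compound, a lower number a less soluble compound), compound 1 gives 50000 nM, the lower of the two numbers known so far. Within the data shown here, its only measured neighbour is compound 2 `O=C1CC[C@@H](C(=O)N2CCC(NS(=O)(=O)c3cc(S(=O)(=O)c4ccccc4)ccc3C(F)(F)F)CC2)N1`, which in this assay gives 100000 nM; the step of a 2.0-fold higher number from compound 1 to compound 2 (0.30 log units; within the scatter) swaps one group on a carbonyl carbon for a ring and stays within the scatter, so the two compounds cannot be ordered. Compound 3 `CCNC(=O)N1CCC[C@H]1C(=O)N1CCC(NS(=O)(=O)c2cc(S(=O)(=O)c3ccccc3)ccc2C(F)(F)F)CC1` has not yet been measured. It differs from compound 1 at the same carbonyl carbon: 1-(ethylcarbamoyl)pyrrolidin-2-yl in place of (piperazin-1-yl)methyl on a carbonyl carbon. Among the measured compounds shown here, the only step that bears on this change is a 2.0-fold higher number from compound 1 to compound 2 (0.30 log units; within the scatter), in which a ring likewise took the place of the (piperazin-1-yl)methyl group and the number barely moved. A similarly small step, if anything downward, is therefore expected for compound 3, namely a 1.7-fold lower number from compound 1 to compound 3 (0.22 log units; within the scatter). Compound 3 is expected to give 30000 nM, between 8000 nM and 100000 nM.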

Compound 3, solubility: 100000 nM
For compound 3 the middle estimate is 3.3-fold (0.52 log units) below the measured one; the range from low to high includes it.
By their numbers in this assay, from the lowest: compounds 1, 2 and 3 (each within the scatter of the next).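

In this assay, putting 1-(ethylcarbamoyl)pyrrolidin-2-yl in place of (piperazin-1-yl)methyl on the carbonyl carbon gives a 2.0-fold higher number from compound 1 to compound 3 (0.30 log units; within the scatter). Exchanging 5-oxopyrrolidin-2-yl for the same group gives no change at the digits printed from compound 2 to compound 3 (within the scatter). This position has now carried three different groups, with a six-membered or a five-membered ring and with differing heavy-atom counts, and the read-out cannot tell any of them apart, so the small first step is no longer a lone observation.

As far as these compounds go, whether a carboxylic acid or a long alkyl chain on this carbonyl carbon would carry the number beyond the scatter remains open, as does the outcome of changes elsewhere on the shared core. No measurement at hand says why these three groups cannot be separated here.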